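From methyl to trifluoromethyl: estimating compound 4

The source may report more compounds than this note shows. Statements on the series, on what has been measured and on what is new or still open speak of the compounds shown alone.

compound 1 `O=C(O)CCNC(=O)c1ccc(C(Oc2ccc(-n3cc(C(F)(F)F)cn3)cc2)C2CCCC2)cc1`: 3.3
compound 2 `CC(C)(C)C(Oc1ccc(-n2cc(C(F)(F)F)cn2)cc1)c1ccc(C(=O)NCCC(=O)O)cc1`: 3.7
compound 3 `CCCC(Oc1ccc(-n2cc(C)cn2)cc1)c1ccc(C(=O)NCCC(=O)O)cc1`: 2.1

In a physicochemical assay for lipophilicity, using the shake flask method, at pH 7.4 (a higher number here means a more lipophilic compound, a lower number a more polar compound), compound 3 stands lowest of the three at 2.1. Compound 4 `CCCC(Oc1ccc(-n2cc(C(F)(F)F)cn2)cc1)c1ccc(C(=O)NCCC(=O)O)cc1` is not yet measured. It differs from compound 3 by a single change, (trifluoromethyl in place of methyl on an aromatic carbon), which is trifluoromethyl in place of methyl on an aromatic carbon. Among the measured compounds shown here, no measured step shows this swap. For the measured compounds named here, the one measured step, a number 0.40 log units higher from compound 1 to compound 2 (beyond the scatter), is a change of tert-butyl for cyclopentyl at another place, so it gives only a sense of scale. Compound 1 at 3.3 and compound 2 at 3.7 both carry trifluoromethyl and sit higher than compound 3, though they also differ from it elsewhere. In this assay, the expected step is a number 0.80 log units higher from compound 3 to compound 4 (beyond the scatter), upward and beyond the scatter. For compound 4 the estimate is 2.9, with an expected range of 2.5 to 3.3.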

Compound 4, distribution coefficient: 2.4
Estimate against measurement, compound 4: 0.50 log units above; the measured number lies below the stated range.
By their numbers in this assay, from the lowest: compounds 3 and 4 (each within the scatter of the next); then compound 1; then compound 2.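

In this assay, trifluoromethyl in place of methyl on this aromatic carbon gives a number 0.30 log units higher from compound 3 to compound 4 (within the scatter) and so cannot be told apart from no change. The chain carbon shows the larger steps: a number 1.30 log units lower from compound 2 to compound 4 (beyond the scatter) with propyl in place of tert-butyl, and a number 0.90 log units lower from compound 1 to compound 4 (beyond the scatter) with propyl in place of cyclopentyl. Nothing measured here gives a reason for the size of these steps.

Going by these compounds, whether the swap stays this small with tert-butyl or cyclopentyl on the chain carbon remains open. So does how a nitrile or an amine on that aromatic carbon would compare.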